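The compounds below may be only part of what the source reports. "The series", "measured", "known", "first", "only" and "open" are said of these compounds alone.

Series notes, substituent on the ring nitrogen of the shared core.

Among the compounds with values here, compound 3 `Cc1cccc2sc(NC(=O)CCN3CCN(C4CCCCC4)CC3)nc12` holds the lowest number of the three so far measured in an assay on membranes from liver for displacement of a labelled ligand from Sigma intracellular receptor 2 (Rattus norvegicus), read by scintillation counting, with a stated time of 120 min (on this read-out higher numbers stand for weaker inhibition and lower numbers for stronger inhibition), where compound 3 gives 233 nM. Compound 1 `CCN1CCN(CCC(=O)Nc2nc3c(C)cccc3s2)CC1` is nearest to it and gives 1200 nM; compound 2 `Cc1cccc2sc(NC(=O)CCN3CCN(CC4CCCO4)CC3)nc12` is furthest and gives 5000 nM. Both gaps lie beyond the scatter, so compound 3 is the strongest inhibitor of the set as it stands.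

Compound 4 `Cc1ccccc1N1CCN(CCC(=O)Nc2nc3c(C)cccc3s2)CC1` is the next step from compound 3: 2-methylphenyl in place of cyclohexyl on an amine nitrogen in a ring. Within the data shown here, no measured pair tests an aromatic group in this place. The two steps that bear on it both end at the cyclohexyl compound: a 5.2-fold lower number from compound 1 to compound 3 (0.71 log units; beyond the scatter), and a 21-fold lower number from compound 2 to compound 3 (1.33 log units; beyond the scatter). Cyclohexyl therefore gave the lowest number against two different saturated groups, but nothing here shows how an aromatic ring of similar size compares with it. A modest step in this assay is expected, with the direction uncertain and a weakening somewhat more likely, since every group tried other than cyclohexyl has given a higher number.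

Compound 4 is therefore estimated at 450 nM in this assay, within 120 nM to 1800 nM; this amounts to an expected step of a 1.9-fold higher number from compound 3 to compound 4 (0.29 log units; within the scatter).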

Compound 4, inhibition constant: > 1000 nM
Compound 4 ended at the assay's limit (the forecaster's own chance of this, stated with the estimate: 3%); middle value at least 2.2-fold (0.34 log units) from the limit.
By their numbers in this assay, from the lowest: compound 3; then compound 1; then compound 2.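

In this assay compound 4 gives > 1000 nM, which is a limit of the assay and not a number. Within the data shown here, this is the first aromatic group seen on this amine nitrogen in a ring, and 2-methylphenyl in place of cyclohexyl gives an at least 4.2-fold higher number from compound 3 to compound 4 (0.63 log units; beyond the scatter), so cyclohexyl now keeps the lowest number against an aromatic ring as well as against the two saturated groups. Compound 4 cannot be placed against compound 1 or compound 2, and the steps to it from those two cannot be read, owing to this: the limit of > 1000 nM in this assay, at which 1 of the 4 values shown sits.

The change swaps the non-aromatic ring for an aromatic one and adds the methyl in a single step, so the compounds shown leave open which of the two carries the higher number, and a plain phenyl group on this nitrogen would separate them. Also open, going by these compounds, is how far the low number of compound 3 depends on the six-membered carbon ring itself, which a cyclopentyl or a benzyl group in this place would test.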